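A few compounds are considered here, and "the series" means these few. Any claim that something is new, unique, unknown or untested is made for them only; others in the source may bear on it.

Measured compounds in an assay on isolated protein for inhibition of sterol O-acyltransferase 1 (Mus musculus), tested at 0.1 uM; a lower number here means less inhibition, a higher number more inhibition at the concentration tested (going by the name of the read-out):
Compound 1 `CCCCCCCCCCCCn1nnc(C(Cc2ccccc2)C(=O)Nc2c(OC)cc(OC)cc2OC)n1` gives 77%.
Compound 2 `CCCCCCCCCCCCn1nnc(C(C(=O)Nc2c(OC)cc(OC)cc2OC)c2ccccn2)n1` gives 23%.

Compound 2 stands lowest of the two numbers; its nearest neighbour is compound 1, and the step of a number 54 percentage points lower from compound 1 to compound 2 (beyond the scatter) lies beyond the scatter. Compound 3 `CCCCCCCCCCCCn1nnc(CC(=O)Nc2c(OC)cc(OC)cc2OC)n1` is not yet measured. It differs from compound 2 thus: hydrogen in place of pyridin-2-yl on a saturated chain carbon bound to an aromatic carbon and a carbonyl carbon. Going by the values given here, only the step of a number 54 percentage points lower from compound 1 to compound 2 (beyond the scatter) bears on this change, and it shows that what sits on this saturated chain carbon moves the number strongly, but no measured step removes the group entirely. Compound 3 is therefore expected at 35%, within 5% to 70%, the estimated step being a number 12 percentage points higher from compound 2 to compound 3 (beyond the scatter), with wide uncertainty in either direction.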

Compound 3, a percentage reported as inhibition, at one concentration (the size of the read-out at that concentration, not a potency): 66%
For compound 3 the middle estimate is 31 percentage points below the measured one; low and high end bracket the measured number.
By their numbers in this assay, from the lowest: compound 2; then compound 3; then compound 1.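

In this assay, hydrogen in place of pyridin-2-yl on the saturated chain carbon gives a number 43 percentage points higher from compound 2 to compound 3 (beyond the scatter), so the low number of compound 2 comes with adding pyridin-2-yl and is not a feature of the shared core. Hydrogen in place of benzyl gives only a number 11 percentage points lower from compound 1 to compound 3 (beyond the scatter), so on this carbon benzyl raises the number modestly, whereas pyridin-2-yl lowers it greatly. Substituents at this position can therefore move the number in either direction from that of compound 3. From the compounds shown here alone, whether phenyl, pyridin-3-yl or methyl on this carbon would follow benzyl or pyridin-2-yl remains open. Nothing available gives a reason for the opposite effects of these two groups.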